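The compounds below may be only part of what the source reports. "The series", "measured", "known", "first", "only" and "open" are said of these compounds alone.

Compound 2 `CN1CCN(CCCOc2cccc3nc(Nc4ccc(F)c(F)c4)ccc23)CC1` gives 3920 nM in a functional assay on SNB-75 cells (Homo sapiens) for inhibition, read by sulforhodamine B assay, with a stated time of 48 h (a lower number here means a stronger inhibitor of growth, a higher number a weaker inhibitor of growth), and stands lowest of the two numbers in hand. Compound 1 `CC(C)c1ccc(Nc2ccc3c(OCCCN4CCN(C)CC4)cccc3n2)cc1` gives 12800 nM in this assay. Within the data shown here, only one measured step bears on the change considered here, an exchange of the ring on the same nitrogen: a 3.3-fold lower number from compound 1 to compound 2 (0.51 log units; beyond the scatter). Compound 3 `CN1CCN(CCCOc2cccc3nc(Nc4cccc(Cl)c4)ccc23)CC1` carries 3-chlorophenyl in place of 3,4-difluorophenyl on a nitrogen on an aromatic ring. A step of similar or smaller size is expected, with no direction firmly indicated. Compound 3 is therefore estimated at 4000 nM in this assay, with a range of 1500 nM to 11000 nM. The expected step is a 1.0-fold higher number from compound 2 to compound 3 (0.01 log units; within the scatter).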

Compound 3, concentration for 50% growth inhibition: 1380 nM
Estimate against measurement, compound 3: 2.9-fold (0.46 log units) above; the whole stated range lies above it.
By their numbers in this assay, from the lowest: compound 3; then compound 2; then compound 1.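

The aryl group on this nitrogen still moves the number when the ring stays and only its halogen substitution changes: in this assay, a 2.8-fold lower number from compound 2 to compound 3 (0.45 log units; beyond the scatter). The 3-chlorophenyl group also gives the widest step in the set, a 9.3-fold lower number from compound 1 to compound 3 (0.97 log units; beyond the scatter), so all three compounds are separated beyond the scatter. Nothing in hand accounts for these differences.

Still open, from the compounds shown here alone, is whether a bromophenyl or methoxyphenyl group on the same nitrogen would follow compound 3. Also open, going by these compounds, is whether the step persists with morpholine in place of the methylpiperazine.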